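The source may report more compounds than this note shows. Statements on the series, on what has been measured and on what is new or still open speak of the compounds shown alone.

Measured so far:
compound 1 `CCCn1c(=O)[nH]c2nc(-c3ccc(S(=O)(=O)N4CCN(c5ccccc5Cl)CC4)cc3)[nH]c2c1=O` gives > 1000 nM
compound 2 `CCCn1c(=O)[nH]c2nc(-c3ccc(S(=O)(=O)N4CCN(c5ccccc5)C(C)C4)cc3)[nH]c2c1=O` gives > 1000 nM

Compound 2 stands only at a limit. In an assay on CHO cells for displacement of a labelled ligand from adenosine receptor A3 (Homo sapiens), read by scintillation counting, with a stated time of 45 min, in the presence of a further agent that is not named here (a higher number here means a weaker inhibitor, a lower number a stronger inhibitor), compound 2 gives > 1000 nM, which is a limit of the assay and not a number. In this assay compound 1 likewise gives > 1000 nM, again a limit. Going by the values given here, both values sit at the limit of > 1000 nM in this assay, at which 2 of the 2 values shown sit, so no step between measured compounds can be sized and nothing separates the two in this assay.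

Compound 3 `CCCn1c(=O)[nH]c2nc(-c3ccc(S(=O)(=O)N4CCN(c5ccccc5)CC4)cc3)[nH]c2c1=O` has not yet been measured in this assay. It differs from compound 2 by hydrogen in place of methyl on a saturated ring carbon. No measured step covers this change, and with both neighbours at the limit no direction can be read from the numbers shown. The step that the limit leaves unreadable from compound 2 to compound 3 is expected to lie within the scatter. It is expected that compound 3 will most likely also return a limit. Compound 3 is estimated at 3000 nM, with a range from 800 nM to 20000 nM.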

Compound 3, inhibition constant: > 1000 nM
Compound 3 ended at the assay's limit (the forecaster's own chance of this, stated with the estimate: 75%); the middle value does not contradict the limit.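

Compound 3 gives > 1000 nM in this assay, a limit of the assay and not a number. No step among compound 1, compound 2 and compound 3 can be read, because all three sit at one limit: the limit of > 1000 nM in this assay, at which 3 of the 3 values shown sit.

The compounds shown leave open whether methyl or chloro changes the inhibition constant in this assay at all.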